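The compounds below may be only part of what the source reports. "The series", "measured", "known", "first", "only" and "open" are said of these compounds alone.

Measured in a functional assay on the whole organism with Mus musculus as the target; on this read-out higher numbers stand for an effect only at larger amounts of compound and lower numbers for an effect already at smaller amounts:
- Compound 1 `O=C1CCC(O)(c2cccc(C(F)(F)F)c2)N1`: > 200 mg/kg, a limit
- Compound 2 `CCN1C(=O)CCC1(O)c1cccc(C(F)(F)F)c1`: > 100 mg/kg, a limit
- Compound 3 `CCCN1C(=O)CCC1(O)c1cccc(C(F)(F)F)c1`: > 200 mg/kg, a limit

No number is available for any of the three. Compound 3 stands at the limit of > 200 mg/kg in this assay, at which 2 of the 3 values shown sit, so its position is known only as a limit.

Compound 4 `CCCCN1C(=O)CCC1(O)c1cccc(C(F)(F)F)c1` extends the propyl chain of compound 3 to butyl: methyl in place of hydrogen on a saturated chain carbon, three bonds along the chain from an amide-type nitrogen in a ring. The closest measured precedent is the ethyl to propyl change, a step that the two limits leave unreadable from compound 2 to compound 3. Replacing the amide hydrogen gives a step that the two limits leave unreadable from compound 1 to compound 2 and a step that the two limits leave unreadable from compound 1 to compound 3. None of these steps has a readable size, so they give no direction for a further carbon on the chain. For the measured compounds named here, they show only that compound 1, compound 2 and compound 3 all ended at limits.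

In this assay, no shift beyond the usual scatter can be supported, so the expected change is a number no higher from compound 3 to compound 4 (the limit leaves the size open). Compound 4 is expected to be reported as a limit as well. For compound 4 the estimated value is 200 mg/kg, with an expected range of 80 mg/kg to 400 mg/kg.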

Compound 4, dose for half-maximal effect: > 200 mg/kg
Compound 4: only a limit was reported (the forecaster's own chance of this, stated with the estimate: 70%); the middle value sits exactly at the limit.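

Compound 4 is reported only as a limit, like compound 1, compound 2 and compound 3, so no step among these compounds can be read. The compounds shown leave open what dose gives half-maximal effect for any of them, and whether chain length on the amide-type nitrogen changes it at all.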